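From 2-chlorophenyl to 4-methoxyphenyl: an expected cytotoxicity value

This account rests on a few compounds, and the source may have more. Where it says the series, first, only, none or still open, it means among the compounds named here.

Compound 1 `O=C(COc1cccc2ccccc12)N/N=C/c1cccc(Br)c1` gives 87.4 ug/mL
Compound 2 `O=C(COc1cccc2ccccc12)N/N=C/c1ccccc1Cl` gives 56.2 ug/mL
Compound 3 `COc1ccc(/C=N/NC(=O)COc2cccc3ccccc23)cc1` is not yet measured

In an ADME assay on MT4 cells (Homo sapiens) for cytotoxicity, read by MTT assay, with a stated time of 4 days (a lower number here means that less compound is tolerated, a higher number that more compound is tolerated), compound 2 stands within the scatter of compound 1 and nothing measured separates them further. Compound 3 differs by 4-methoxyphenyl in place of 2-chlorophenyl on a carbon with a double bond to nitrogen on a carbon with a double bond to nitrogen. Going by the values given here, the only measured change at that place is a 1.6-fold lower number from compound 1 to compound 2 (0.19 log units; within the scatter) and so no step beyond the scatter is expected, though a single step is thin evidence. The expected step is a 1.2-fold higher number from compound 2 to compound 3 (0.10 log units; within the scatter) and stays within the scatter. Compound 3 is estimated at 70 ug/mL with an expected range from 30 ug/mL to 150 ug/mL.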

Compound 3, half-maximal cytotoxic concentration: 76.9 ug/mL
For compound 3 the middle estimate is 1.1-fold (0.04 log units) below the measured one; the measured number falls inside the stated range.
By their numbers in this assay, from the lowest: compounds 2, 3 and 1 (each within the scatter of the next).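

In this assay, 4-methoxyphenyl on the carbon with a double bond to nitrogen gives a 1.4-fold higher number from compound 2 to compound 3 (0.14 log units; within the scatter) and a 1.1-fold lower number from compound 1 to compound 3 (0.06 log units; within the scatter), so both steps stay within the scatter. The earlier compounds shown here carried only halogen-bearing phenyl groups, whereas this one shows that a methoxy-bearing phenyl group, with its hydrogen-bond acceptor, also leaves the number within the scatter of both. Nothing available explains why these numbers stay so close. The compounds shown leave open whether an amine, a carboxylic acid or a longer chain at this place would move the number beyond the scatter.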